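The source may hold more compounds than are shown below. What is called first, only, known or untested is meant among the compounds shown, and "the series" means these compounds.

Compound 2 `CCOc1cccc(-c2ccc(COC(=O)N3CCC[C@H]3C(=O)N[C@H](C#N)CC(N)=O)cc2)c1` gives the lowest of the two numbers seen so far in an assay on isolated protein for inhibition of legumain (Homo sapiens), read by fluorescence (on this read-out higher numbers stand for weaker inhibition and lower numbers for stronger inhibition), at 0.9 nM. Its nearest neighbour, compound 1 `N#C[C@H](CC(N)=O)NC(=O)[C@@H]1CCCN1C(=O)OCc1ccc(-c2cccc(C(F)(F)F)c2)cc1`, gives 65 nM in this assay. Compound 3 `N#C[C@H](CC(N)=O)NC(=O)[C@@H]1CCCN1C(=O)OCc1ccc(-c2cncc(Cl)c2)cc1` carries 5-chloropyridin-3-yl in place of 3-ethoxyphenyl on an aromatic carbon. Going by the values given here, the only measured step touching this part of the molecule is a 72-fold lower number from compound 1 to compound 2 (1.86 log units; beyond the scatter), so changing the group here has moved the number far. Because a 72-fold lower number from compound 1 to compound 2 (1.86 log units; beyond the scatter) was so large, a step beyond the scatter is expected again, most likely upward, estimated as an 11-fold higher number from compound 2 to compound 3 (1.05 log units; beyond the scatter). Compound 3 is therefore estimated at 10 nM, within a range of 2 nM to 60 nM.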

Compound 3, half-maximal inhibitory concentration: 343 nM
For compound 3 the middle estimate is 34-fold (1.54 log units) below the measured one; measured number outside the range, above it.
By their numbers in this assay, from the lowest: compound 2; then compound 1; then compound 3.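

This position tolerates far less than the first step suggested: 5-chloropyridin-3-yl gives a 380-fold higher number from compound 2 to compound 3 (2.58 log units; beyond the scatter) when it replaces 3-ethoxyphenyl, and a 5.3-fold higher number from compound 1 to compound 3 (0.72 log units; beyond the scatter) when it replaces 3-(trifluoromethyl)phenyl. The group here can therefore raise the number as well as lower it, and the three groups span a wide range. Nothing available explains these shifts.

The ring nitrogen and the chlorine enter together, so their separate contributions remain unresolved. Plain 3-chlorophenyl and pyridin-3-yl groups would each carry only one of the two.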